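A few compounds are considered here, and "the series" means these few. Any claim that something is new, unique, unknown or untested is made for them only; others in the source may bear on it.

Three compounds built on one shared core were tested in an ADME assay on NCM460 cells (Homo sapiens) for cytotoxicity, read by CCK-8 assay, with a stated time of 48 h; on this read-out lower numbers stand for stronger inhibition and higher numbers for weaker inhibition. Compound 1 `COc1ccc(/C=C\c2cc(OC)c(OC)c(OC)c2)cc1OCc1ccc(CN2CC[C@@H](C(=O)O)C2)cc1` gives in this assay only a limit of the assay, > 50000 nM. Compound 2 `COc1ccc(/C=C\c2cc(OC)c(OC)c(OC)c2)cc1OCc1ccc(CN2CC[C@H](O)C2)cc1` gives 51000 nM in this assay. Compound 3 `COc1ccc(/C=C\c2cc(OC)c(OC)c(OC)c2)cc1OCc1ccc(CN2CCCCC2C(=O)NCCN)cc1` likewise gives only a limit, > 50000 nM. Where compound 3 stands among the three can thus be said no more closely than that it sits at the limit of > 50000 nM in this assay, at which 2 of the 3 values shown sit.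

Compound 4 `COc1ccc(/C=C\c2cc(OC)c(OC)c(OC)c2)cc1OCc1ccc(CN2CCCC[C@@H]2C(=O)O)cc1` differs from compound 3 by 2-carboxypiperidin-1-yl in place of 2-((2-aminoethyl)carbamoyl)piperidin-1-yl on a saturated chain carbon bound to an aromatic carbon. The measured steps that touch this same place are a step that the two limits leave unreadable from compound 1 to compound 3 and a step that the limit leaves unreadable from compound 2 to compound 3, and also a step that the limit leaves unreadable from compound 1 to compound 2; none of them has a readable size, so no direction can be drawn from them. All three measured compounds sit at or close to the limit, and compound 4 is expected to stay in that region too. The expected step that the limit leaves unreadable from compound 3 to compound 4 is meant as no change beyond the scatter. The estimate for compound 4 in this assay is 60000 nM, with a range from 30000 nM to 150000 nM.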

Compound 4, half-maximal inhibitory concentration: > 50000 nM
Compound 4 gave a limit, no number (the forecaster's own chance of this, stated with the estimate: 70%); the middle value lies beyond the limit too.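

Compound 4 gives only a limit in this assay, > 50000 nM. Going by these compounds alone, no step from compound 1, compound 2 or compound 3 to compound 4 can therefore be read. The compounds shown leave open how these four rank against one another, with most values resting at one point: the limit of > 50000 nM in this assay, at which 3 of the 4 values shown sit.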